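From diethylamino to cyclohexylamino: an expected small step

A few compounds are considered here, and "the series" means these few. Any claim that something is new, unique, unknown or untested is made for them only; others in the source may bear on it.

compound 1 `CCNC(=O)c1nnn(-c2cc(C(C)C)c(O)cc2O)c1-c1ccc(CN2CCC[C@@H](O)C2)cc1`: 52 nM
compound 2 `CCNC(=O)c1nnn(-c2cc(C(C)C)c(O)cc2O)c1-c1ccc(CN2CCCC2)cc1`: 3 nM
compound 3 `CCNC(=O)c1nnn(-c2cc(C(C)C)c(O)cc2O)c1-c1ccc(CN(CC)CC)cc1`: 11 nM

These three compounds were tested in a functional assay on NCI-H460 cells (Homo sapiens) for inhibition, read by sulforhodamine B assay, with a stated time of 72 h (on this read-out higher numbers stand for weaker inhibition and lower numbers for stronger inhibition), where compound 3, at 11 nM, stands second highest of the three numbers. The next compound, compound 4 `CCNC(=O)c1nnn(-c2cc(C(C)C)c(O)cc2O)c1-c1ccc(CNC2CCCCC2)cc1`, keeps the shared core and changes one group: cyclohexylamino in place of diethylamino on a saturated chain carbon bound to an aromatic carbon. Here cyclohexylamino takes the place of diethylamino on a saturated chain carbon bound to an aromatic carbon.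

All three measured steps involve a swap at this same place. The number can fall, as in the modest 4.7-fold lower number from compound 1 to compound 3 (0.67 log units; beyond the scatter) and the large 17-fold lower number from compound 1 to compound 2 (1.24 log units; beyond the scatter), or rise, as in the modest 3.7-fold higher number from compound 2 to compound 3 (0.56 log units; beyond the scatter). So this place clearly matters in this assay, but no measured compound carries cyclohexylamino, and the steps give no firm direction for this swap. A small rise, not beyond the scatter, is therefore the cautious expectation. The expected change is a 1.4-fold higher number from compound 3 to compound 4 (0.13 log units; within the scatter). The estimated value for compound 4 is 15 nM, with an expected range of 5 nM to 45 nM.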

Compound 4, half-maximal inhibitory concentration: 15 nM
The estimate for compound 4 equals the measured number at the digits printed, within the range that was stated.
By their numbers in this assay, from the lowest: compound 2; then compounds 3 and 4 (each within the scatter of the next); then compound 1.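

In this assay, cyclohexylamino brings a six-membered non-aromatic ring of carbon only and a hydrogen-bond donor that diethylamino lacks, yet the swap gives a 1.4-fold higher number from compound 3 to compound 4 (0.13 log units; within the scatter) and so does not separate these two groups at this place. The other two comparisons place cyclohexylamino on the same footing as diethylamino: pyrrolidin-1-yl still gives the lower number, with a 5.0-fold higher number from compound 2 to compound 4 (0.70 log units; beyond the scatter), while 3-hydroxypiperidin-1-yl gives the higher one, as a 3.5-fold lower number from compound 1 to compound 4 (0.54 log units; beyond the scatter) shows. No measurement here offers an explanation for these differences.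

A plain piperidin-1-yl group would show whether the hydroxyl or the ring of 3-hydroxypiperidin-1-yl goes with its higher number. A cyclohexyl(methyl)amino group, which has no hydrogen on its nitrogen, would show whether the donor of cyclohexylamino matters at this place.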